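The source may hold more compounds than are shown below. What is called first, only, known or untested is meant among the compounds shown, and "the series" means these compounds.

- Compound 1 `CC(C)[C@H](NC(=O)COc1cccc2ccccc12)C(=O)N[C@@H](CC(=O)O)C(=O)COC(=O)c1c(Cl)cccc1Cl`: 10600 nM
- Compound 2 `CC(=O)Nc1cccc(OCC(=O)[C@H](CC(=O)O)NC(=O)[C@@H](NC(=O)COc2cccc3ccccc23)C(C)C)c1`: > 100000 nM (a limit)
- Compound 3 `CC(C)[C@H](NC(=O)COc1cccc2ccccc12)C(=O)N[C@@H](CC(=O)O)C(=O)COc1ccc([N+](=O)[O-])cc1`: > 100000 nM (a limit)

All three were tested in a functional assay on Jurkat cells (Homo sapiens); on this read-out higher numbers stand for weaker inhibition and lower numbers for stronger inhibition. Compound 3 reads > 100000 nM, which is a limit and not a number. Compound 4 `CC(C)[C@H](NC(=O)COc1cccc2ccccc12)C(=O)N[C@@H](CC(=O)O)C(=O)COc1ccc(F)c(F)c1` carries 3,4-difluorophenyl in place of 4-nitrophenyl on an oxygen on a saturated carbon. The closest measured swap gives a step that the two limits leave unreadable from compound 2 to compound 3. The other two measured steps, an at least 9.4-fold higher number from compound 1 to compound 2 (0.97 log units; beyond the scatter) and an at least 9.4-fold higher number from compound 1 to compound 3 (0.97 log units; beyond the scatter), show that both substituted phenyl groups on that oxygen fall well short of the (2,6-dichlorophenyl)carbonyl group. Compound 4 also has a substituted phenyl there, so it is expected to stay weak, near (the limit of > 100000 nM in this assay, at which 2 of the 3 values shown sit). The expected change is small, toward stronger inhibition if any, as an at least 1.4-fold lower number from compound 3 to compound 4 (0.15 log units; that floor lies within the scatter). For compound 4 the estimated value is 70000 nM, with an expected range from 20000 nM to 200000 nM.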

Compound 4, half-maximal inhibitory concentration: > 100000 nM
Compound 4: a limit, no number (the forecaster's own chance of this, stated with the estimate: 55%); at least 1.4-fold (0.15 log units) between middle value and limit.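

In this assay, putting 3,4-difluorophenyl in place of (2,6-dichlorophenyl)carbonyl on this oxygen gives an at least 9.4-fold higher number from compound 1 to compound 4 (0.97 log units; beyond the scatter). This third phenyl group has only fluorine as its substituents, unlike the nitrogen-bearing groups of compound 2 and compound 3, yet it gives the same result, so the loss does not hang on those groups: the limit of > 100000 nM in this assay, at which 3 of the 4 values shown sit. The steps among compound 2, compound 3 and compound 4 join limits and cannot be read.

Going by these compounds, it remains open whether the carbonyl or the two chlorine atoms of compound 1 matter more. An unsubstituted benzoyl group or a 2,6-dichlorophenyl group on that oxygen would separate the two.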